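Toward compound 4: a trifluoromethyl for a chloro

The source may hold more compounds than are shown below. What is called first, only, known or untested is meant among the compounds shown, and "the series" means these compounds.

Compound 1, `COc1cc(-c2nn(-c3cccc(NC(=O)Nc4ccc(Cl)c(Cl)c4)c3)cc2-c2ccncc2)ccc1Cl`: in a functional assay on BT-549 cells (Homo sapiens) for inhibition, read by sulforhodamine B assay, with a stated time of 48 h (on this read-out higher numbers stand for lower toxicity in this test and lower numbers for higher toxicity in this test), compound 1 reaches only the limit > 50000 nM.
Compound 2, `O=C(Nc1cccc(-n2cc(-c3ccncc3)c(-c3ccc(Cl)c(O)c3)n2)c1)Nc1ccc(Cl)c(Cl)c1`: in this assay compound 2 reaches only the limit > 32500 nM.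
Compound 3, `COc1cc(-c2nn(-c3cccc(NC(=O)c4ccc(Cl)c(C(F)(F)F)c4)c3)cc2-c2ccncc2)ccc1Cl`: in this assay compound 3 reaches only the limit > 32500 nM.

None of the three measured compounds gives a number in this assay; each result is a limit of the test. Compound 2 therefore stands at a limit, as do the two other values shown, and nothing places it above or below its neighbours. The two measured steps, a step that the two limits leave unreadable from compound 1 to compound 2 and a step that the two limits leave unreadable from compound 1 to compound 3, are both unreadable, since both ends are limits; the evidence is no more than the limit of > 32500 nM in this assay, at which 2 of the 3 values shown sit, and (the limit of > 50000 nM in this assay, at which 1 of the 3 values shown sits).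

Compound 4, `O=C(Nc1cccc(-n2cc(-c3ccncc3)c(-c3ccc(Cl)c(O)c3)n2)c1)Nc1ccc(Cl)c(C(F)(F)F)c1`, differs from compound 2 by trifluoromethyl in place of chloro on an aromatic carbon. The step from compound 1 to compound 3 is the only measured one touching the same part of the molecule, and it shows no readable size. Compound 4 is therefore expected to sit at a limit as well, with an expected step that the limit leaves unreadable from compound 2 to compound 4 that cannot be distinguished from none. The estimate for compound 4 is 60000 nM, within 25000 nM to 150000 nM, and the measurement is most likely to be reported again as a limit.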

Compound 4, concentration lethal to 50% of the cells: > 32500 nM
Compound 4 ended at the assay's limit (the forecaster's own chance of this, stated with the estimate: 85%); the middle value does not contradict the limit.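

Compound 2 and compound 4 both stop at a limit of the test, so the step between them, trifluoromethyl in place of chloro, cannot be read. The compounds shown leave open where any of them would give an actual number in this assay, and whether this exchange changes that number at all.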